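Solubility notes on the amide series: compound 2 to compound 4

This account rests on a few compounds, and the source may have more. Where it says the series, first, only, none or still open, it means among the compounds named here.

In a physicochemical assay for solubility, with a stated time of 24 h, at pH 2.2 (a lower number here means a less soluble compound, a higher number a more soluble compound), compound 2 `O=C(NCCO)c1ccc2ccc(C(=O)c3ccccc3)c-2cc1` gives 14 ug/mL, the lowest of the two numbers in hand. Compound 3 `O=C(Nc1cc2cccccc-2c1)c1cccnc1` gives 43 ug/mL, a step up from compound 2 that lies beyond the scatter. Compound 1 `Cn1c(NC(=O)c2cccnc2)cc2ccccc21` sits at the limit of > 59 ug/mL in this assay, at which 1 of the 3 values shown sits. In this assay compound 1 gives > 59 ug/mL, which is a limit and not a number.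

Compound 4 `O=C(NCc1cccnc1)c1ccc2ccc(C(=O)c3ccccc3)c-2cc1` has not yet been measured in this assay. It differs from compound 2 in one place: pyridin-3-yl in place of hydroxymethyl on a saturated chain carbon bound to an amide-type nitrogen. Going by the values given here, no measured pair reproduces this change, so its size must be guessed. Compounds 1 and 3 both carry a pyridin-3-yl group and hold the upper two values shown, while compound 2 carries the hydroxymethyl and holds the lowest; the cores differ, however, so this is weak ground and no pattern is claimed. The expected step of a 2.1-fold higher number from compound 2 to compound 4 (0.33 log units; beyond the scatter) is a modest rise, possibly beyond the scatter. Compound 4 is estimated at 30 ug/mL, with a range of 10 ug/mL to 90 ug/mL, and a reading that is only a limit cannot be excluded.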

Compound 4, solubility: 70 ug/mL
Estimate against measurement, compound 4: 2.3-fold (0.37 log units) below, within the range that was stated.
By their numbers in this assay, from the lowest: compound 2; then compounds 3 and 4 (each within the scatter of the next).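

In this assay, going by these compounds alone, the change from hydroxymethyl to pyridin-3-yl on a saturated chain carbon bound to an amide-type nitrogen gives a 5.0-fold higher number from compound 2 to compound 4 (0.70 log units; beyond the scatter), the only step read between compounds that differ in one place. The reading at this position therefore responds to the group carried there, by a margin beyond the scatter. The entering group has one six-membered aromatic ring and 0 hydrogen-bond donors, the leaving group no ring and 1 hydrogen-bond donor, and this single pair cannot separate those differences, nor does any measured property shown account for the step.

Open, going by these compounds, is whether an amine, a carboxylic acid or a longer chain at this place would give a step of like size. Also open, on these data alone, is whether the same change gives a like step on the cores of compound 1 and compound 3, neither of which has a partner differing in one place.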